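Trimming the Hydroxyalkyl Chain to a Methyl Group

A few compounds are considered here, and "the series" means these few. Any claim that something is new, unique, unknown or untested is made for them only; others in the source may bear on it.

Compound 2 `CC(C)(O)Cn1nc(-c2cc(C3CC3)on2)c2c(N)ncnc21` stands second highest of the three numbers measured in an assay on isolated protein for inhibition of proto-oncogene tyrosine-protein kinase receptor Ret (Homo sapiens), read by radiometric assay and 33P incorporation, in the presence of a further agent that is not named here (a higher number here means a weaker inhibitor, a lower number a stronger inhibitor), where compound 2 gives 68 nM. Compound 1 `Nc1ncnc2c1c(-c1cc(C3CC3)on1)nn2C1CCCCC1` gives 2 nM, and compound 3 `CC(C)n1nc(/C=N/O)c2c(N)ncnc21` gives 4900 nM. Compound 4 `Cn1nc(-c2cc(C3CC3)on2)c2c(N)ncnc21` differs from compound 2 by hydrogen in place of 1-hydroxy-1-methylethyl on a saturated chain carbon bound to an aromatic nitrogen. Among the compounds with values here, one measured step bears on this change: a 34-fold higher number from compound 1 to compound 2 (1.53 log units; beyond the scatter), which shows that the group on the aromatic nitrogen moves this assay strongly. Within the data shown here, compound 3 shares no single-point step with compound 2 and only shows a far higher number. Compound 4 is therefore expected to give a higher number, an estimated step of a 3.7-fold higher number from compound 2 to compound 4 (0.57 log units; beyond the scatter) in this assay. Its value for compound 4 is estimated at 250 nM, within a range from 50 nM to 1200 nM.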

Compound 4, half-maximal inhibitory concentration: 27 nM
Compound 4: middle estimate off by 9.3-fold (0.97 log units), on the high side; measured number below the stated range.
By their numbers in this assay, from the lowest: compound 1; then compound 4; then compound 2; then compound 3.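

Cutting 2-hydroxy-2-methylpropyl back to methyl gives a 2.5-fold lower number from compound 2 to compound 4 (0.40 log units; beyond the scatter) in this assay, so at this aromatic nitrogen the hydroxyalkyl chain is not needed for a lower number. Cyclohexyl still stands apart, with a 14-fold higher number from compound 1 to compound 4 (1.13 log units; beyond the scatter), which places methyl in the middle of the three groups and shows that the number does not track the heavy-atom count of the group in a steady line. Nothing given here explains either step. From the compounds shown here alone, whether an isobutyl chain, which lacks the hydroxyl, or a cyclopentyl ring would bring the number closer to that of compound 1 remains open.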